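This account rests on a few compounds, and the source may have more. Where it says the series, first, only, none or still open, it means among the compounds named here.

Compound 1 `CC(C)(C)OC(=O)NCCCCCN1C(Nc2ccc(-c3ccccc3)cc2)=Nc2ccccc2C1CC(=O)NCc1ccccc1` gives 1590 nM in a functional assay on SK-MEL-2 cells (Homo sapiens) for inhibition, read by sulforhodamine B assay, with a stated time of 72 h; on this read-out lower numbers stand for stronger inhibition of growth and higher numbers for weaker inhibition of growth.
Compound 2 `O=C(CC1c2ccccc2N=C(N2CCCCC2)N1c1ccccc1)NCc1ccc(NS(=O)(=O)c2ccc(F)cc2)cc1` gives 1730 nM in this assay.

The numbers of compound 2 and compound 1 lie within the usual scatter of each other, so on this read-out the two cannot be told apart. Compound 3 `CCN1C(N2CCCCC2)=Nc2ccccc2C1CC(=O)NCc1ccc(NS(=O)(=O)c2ccc(F)cc2)cc1` is compound 2 with ethyl in place of phenyl on an amine nitrogen in a ring. Going by the values given here, no measured pair shows what such a change does here, so the forecast rests on compound 2 alone, and a modest rise in the number, a little beyond the scatter, is what is expected. The step is expected to be a 2.0-fold higher number from compound 2 to compound 3 (0.31 log units; beyond the scatter). Compound 3 is estimated at 3500 nM, with a likely range from 1200 nM to 10000 nM.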

Compound 3, concentration for 50% growth inhibition: 17000 nM
The estimate for compound 3 lay 4.9-fold (0.69 log units) below the measured number; the measured number lies above the stated range.
By their numbers in this assay, from the lowest: compounds 1 and 2 (each within the scatter of the next); then compound 3.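

Phenyl and ethyl on this ring amine nitrogen are not interchangeable: the change gives a 9.8-fold higher number from compound 2 to compound 3 (0.99 log units; beyond the scatter) in this assay, so growth inhibition is clearly weaker with the small, ring-free ethyl group. The position therefore affects activity, at least with the piperidin-1-yl group kept in place. Nothing measured here explains why the step is so large.

Going by these compounds, whether benzyl or a longer chain such as butyl would restore the number of compound 2 remains open. So does whether a methoxy group on the phenyl ring would strengthen inhibition.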